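Swapping the bicyclic amide of compound 3 for compound 4

The source may report more compounds than this note shows. Statements on the series, on what has been measured and on what is new or still open speak of the compounds shown alone.

The series shares a piperidine sulfonamide on an aryl ring joined through an amide to a fused bicyclic aromatic. Compound 1 `O=C(Nc1ccc(S(=O)(=O)N2CCCCC2)cc1)c1cc2cnccc2[nH]1` carries the amide directly on the aryl ring, and in an assay for inhibition of Nicotinamide phosphoribosyltransferase (Homo sapiens), read by mass spectrometry, with stated times of 15 min and 30 min (a higher number here means a weaker inhibitor, a lower number a stronger inhibitor), compound 1 gives only a limit, > 10000 nM. Compound 2 `O=C(NCc1ccc(S(=O)(=O)N2CCCCC2)cc1)c1cc2cnccc2o1` inserts a methylene and gives 140 nM in this assay. Compound 3 `O=C(NCc1ccc(S(=O)(=O)N2CCCCC2)cc1)c1cc2ccncc2[nH]1` keeps that methylene but changes the bicyclic amide, and it gives 1000 nM in this assay, the higher of the two numbers in hand, compound 2 being the nearest neighbour after the step of a 7.1-fold higher number from compound 2 to compound 3 (0.85 log units; beyond the scatter).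

Compound 4 `O=C(NCc1ccc(S(=O)(=O)N2CCCCC2)cc1)c1ccn2ccnc2c1` is the next variation: a group of 9 heavy atoms (7 carbon, 2 nitrogen; one five-membered aromatic ring with 2 hetero atoms, one six-membered aromatic ring with 1 hetero atom) in place of a group of 9 heavy atoms (7 carbon, 2 nitrogen; one five-membered aromatic ring with 1 hetero atom, one six-membered aromatic ring with 1 hetero atom), on a carbonyl carbon. For the measured compounds named here, the only step that speaks to a change at this position is the one from compound 2 to compound 3, a modest change. An exchange of the same size in either direction seems plausible, so compound 4 is expected to land near compound 3, with a small gain as the more likely outcome, a step of a 2.0-fold lower number from compound 3 to compound 4 (0.30 log units; within the scatter). Compound 4 is therefore estimated at 500 nM in this assay, within a range from 100 nM to 3000 nM.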

Compound 4, half-maximal inhibitory concentration: 1800 nM
For compound 4 the middle estimate is 3.6-fold (0.56 log units) below the measured one; the range from low to high includes it.
By their numbers in this assay, from the lowest: compound 2; then compounds 3 and 4 (each within the scatter of the next). At a limit, above all of these: compound 1.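

In this assay the exchange at this carbonyl carbon, with the same atoms joined differently, gives a 1.8-fold higher number from compound 3 to compound 4 (0.26 log units; within the scatter), although the count goes from 1 hydrogen-bond donor and 1 acceptor to 0 donors and 2 acceptors. For this pair, then, the change in donors and acceptors comes with no shift beyond the scatter, and the two groups cannot be told apart. The larger separation is from the oxygen-containing group, with a 13-fold higher number from compound 2 to compound 4 (1.11 log units; beyond the scatter) matching the earlier 7.1-fold higher number from compound 2 to compound 3 (0.85 log units; beyond the scatter) in direction, so both groups with 2 nitrogens stand apart from compound 2 beyond the scatter.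

On these data alone, whether a group holding sulfur in place of that oxygen, or one carrying an added amine, would fall nearer compound 2 stays open. Nothing measured here explains these steps.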